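Swapping the para group: trifluoromethyl to fluoro

This account rests on a few compounds, and the source may have more. Where it says the series, first, only, none or still open, it means among the compounds named here.

Compound 1 `CCOC(=O)c1ccc(NC(=O)N2CC2C#N)cc1` is a urea carrying an ethoxycarbonyl group on its aromatic ring. In a functional assay on L1210 cells (Mus musculus) for inhibition, read by MTT assay (a higher number here means a weaker inhibitor, a lower number a stronger inhibitor), compound 1 gives 9700 nM. Compound 2 `N#CC1CN1C(=O)Nc1ccc(C(F)(F)F)cc1` carries a trifluoromethyl group in that position instead, and in this assay compound 2 gives 7100 nM. Going by the values given here, the step of a 1.4-fold lower number from compound 1 to compound 2 (0.14 log units; within the scatter) is the only measured comparison available, so compound 2 stands beside compound 1 with no separation beyond the scatter between them.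

Compound 3 `N#CC1CN1C(=O)Nc1ccc(F)cc1` keeps the shared core and differs from compound 2 as follows: fluoro in place of trifluoromethyl on an aromatic carbon. Among the compounds with values here, the one measured step, which also exchanges the group on this aromatic carbon, was within the scatter, so a similar outcome is expected here, with no step beyond the scatter in this assay. Compound 3 is therefore expected to give about 8000 nM, between 4000 nM and 16000 nM, which corresponds to an estimated step of a 1.1-fold higher number from compound 2 to compound 3 (0.05 log units; within the scatter).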

Compound 3, half-maximal inhibitory concentration: 5900 nM
The estimate for compound 3 lay 1.4-fold (0.13 log units) above the measured number; measured number inside the range.
By their numbers in this assay, from the lowest: compounds 3, 2 and 1 (each within the scatter of the next).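

In this assay, replacing trifluoromethyl (4 heavy atoms) with the single fluorine atom of fluoro gives a 1.2-fold lower number from compound 2 to compound 3 (0.08 log units; within the scatter) and replacing ethoxycarbonyl with fluoro gives a 1.6-fold lower number from compound 1 to compound 3 (0.22 log units; within the scatter) on the same aromatic carbon. Going by these compounds alone, the earlier pair showed only that two larger groups could be exchanged without a step beyond the scatter; compound 3 extends this to a group of one heavy atom, so all three compounds stay within the scatter of one another. No supporting measurement is available to explain why this exchange leaves the number so little changed.

From the compounds shown here alone, whether an amine, a hydroxyl group or a carboxylic acid on this aromatic carbon would produce a step beyond the scatter remains open. So does the result of replacing the nitrile on the shared core with a longer chain.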